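Removing the last chloro from the benzyl group

The compounds below may be only part of what the source reports. "The series", "measured", "known", "first", "only" and "open" are said of these compounds alone.

compound 1 `CC1CCN(Cc2ccc3nc(NC(=O)N/N=C/c4cn(Cc5ccc(Cl)cc5Cl)c5ccccc45)sc3c2)CC1` gives 3640 nM
compound 2 `CC1CCN(Cc2ccc3nc(NC(=O)N/N=C/c4cn(Cc5ccccc5Cl)c5ccccc45)sc3c2)CC1` gives 3330 nM

In a functional assay on A549 cells (Homo sapiens) for cytotoxicity, read by MTT assay, with a stated time of 72 h (on this read-out lower numbers stand for stronger inhibition and higher numbers for weaker inhibition), compound 2 gives 3330 nM. For the measured compounds named here, this lies within the scatter of compound 1, the only other compound measured, so the two cannot be ranked. The next compound, compound 3 `CC1CCN(Cc2ccc3nc(NC(=O)N/N=C/c4cn(Cc5ccccc5)c5ccccc45)sc3c2)CC1`, has not yet been measured. It differs from compound 2 as follows: hydrogen in place of chloro on an aromatic carbon. This turns 2-chlorobenzyl into benzyl, placing hydrogen in place of chloro on an aromatic carbon, ortho to a large group.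

One measured step is of the same kind, a 1.1-fold lower number from compound 1 to compound 2 (0.04 log units; within the scatter). That single step is small, though it cannot show how the remaining chloro will behave. No shift beyond the scatter is therefore expected in this assay. The estimated step is a 1.0-fold higher number from compound 2 to compound 3 (0.01 log units; within the scatter). For compound 3 the expected value is 3400 nM, within an estimated range of 1700 nM to 6800 nM.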

Compound 3, half-maximal inhibitory concentration: 2340 nM
Estimate against measurement, compound 3: 1.5-fold (0.16 log units) above; the measured number falls inside the stated range.
By their numbers in this assay, from the lowest: compounds 3, 2 and 1 (each within the scatter of the next).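

In this assay, the change from 2-chlorobenzyl to benzyl gives a 1.4-fold lower number from compound 2 to compound 3 (0.15 log units; within the scatter) and so stays within the scatter, which means that the chloro ortho to a large group can also give way to hydrogen without a separable change on this read-out. The combined change, phenyl in place of 2,4-dichlorophenyl on a saturated chain carbon bound to an aromatic nitrogen, gives a 1.6-fold lower number from compound 1 to compound 3 (0.19 log units; within the scatter) and is also within the scatter, so the three compounds cannot be ranked. No measured evidence bears on the reason for this result.

As far as these compounds go, what stays open is whether a different group on this aromatic ring, such as methoxy or a carboxylic acid, would move the number beyond the scatter. From the compounds shown here alone, it is equally open whether an amine or a longer chain in place of the benzyl group would do so.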